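The compounds below may be only part of what the source reports. "The series", "measured", "known", "first", "only" and "open" are said of these compounds alone.

Compound 1 `C=Cc1nc2ccccc2s1` carries a vinyl on its core, compound 2 `C#Cc1nc2ccccc2s1` an ethynyl at the same spot. In a functional assay on HCT-116 cells (Homo sapiens) for cytotoxicity, with a stated time of 3 days (a lower number here means a stronger inhibitor, a higher number a weaker inhibitor), compound 1 gives only a limit of the assay, > 40000 nM. In this assay compound 2 gives 19600 nM. The measured step is an at least 2.0-fold lower number from compound 1 to compound 2 (0.30 log units; that floor lies within the scatter), made by ethynyl in place of vinyl on an aromatic carbon.

Compound 3 `C=Cc1csc(Br)n1` stands on a different core; the difference between the two cores is not broken down here. In this assay compound 3 gives only a limit, > 40000 nM, sitting at the limit of > 40000 nM in this assay, at which 2 of the 3 values shown sit. Compound 4 `C#Cc1csc(Br)n1` is not yet measured and carries the same kind of change, (ethynyl in place of vinyl on an aromatic carbon). Around the place the surroundings differ: in compound 2 the ring is part of a fused or bridged system of two rings, next to the ring sulfur, whereas in compound 4 the change sits two ring bonds from the ring sulfur and two ring bonds from the ring atom that bears a bromo group.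

A step of about an at least 1.1-fold lower number from compound 3 to compound 4 (0.05 log units; that floor lies within the scatter) is expected. This rests on compound 2 and its step of an at least 2.0-fold lower number from compound 1 to compound 2 (0.30 log units; that floor lies within the scatter), itself only a floor within the scatter. Compound 4 is estimated at 35000 nM, expected between 12000 nM and 90000 nM.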

Compound 4, half-maximal inhibitory concentration: > 40000 nM
Compound 4: a limit, no number; the forecaster's own chance of this, stated with the estimate: 55%; middle value at least 1.1-fold (0.05 log units) away from the limit.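

Compound 3 and compound 4 both give only a limit, so no step between them can be read: the limit of > 40000 nM in this assay, at which 3 of the 4 values shown sit.

From the compounds shown here alone, whether ethynyl in place of vinyl changes the number on the core of compound 3 stays open.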